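The compounds below may be only part of what the source reports. "The series", "measured", "known", "first", "only" and "open" are said of these compounds alone.

Compound 1 `CC(=O)Nc1c(C(O)(C(F)(F)F)C(F)(F)F)ccc2ccccc12` gives 18 nM in an assay on LtK cells with ATP-sensitive inward rectifier potassium channel 11 (Homo sapiens) as the target (a lower number here means that less compound is needed, a higher number that more compound is needed for the effect), the lowest of the two numbers measured. Compound 2 `CCC(CC)C(=O)Nc1c(C(O)(C(F)(F)F)C(F)(F)F)ccc2ccccc12` gives 4340 nM, and the step of a 240-fold higher number from compound 1 to compound 2 (2.38 log units; beyond the scatter) shows how strongly enlarging the group on the carbonyl carbon raises the number. Compound 3 `O=C(Nc1c(C(O)(C(F)(F)F)C(F)(F)F)ccc2ccccc12)C1CC1` differs from compound 1 by cyclopropyl in place of methyl on a carbonyl carbon. Since cyclopropyl adds fewer atoms than pentan-3-yl did, a rise is expected for compound 3, but a smaller one than from compound 1 to compound 2, estimated as an 8.3-fold higher number from compound 1 to compound 3 (0.92 log units; beyond the scatter). Compound 3 is therefore expected at 150 nM, within 40 nM to 800 nM.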

Compound 3, half-maximal effective concentration: 751 nM
Compound 3: the middle estimate sits 5.0-fold (0.70 log units) below what was measured; measured number inside the range.
By their numbers in this assay, from the lowest: compound 1; then compound 3; then compound 2.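

Even the small cyclopropyl ring on the carbonyl carbon costs a great deal: in place of methyl it brings a 42-fold higher number from compound 1 to compound 3 (1.62 log units; beyond the scatter), so a large rise does not need a group as big as pentan-3-yl. Yet this position still tells the two larger groups apart, with a 5.8-fold lower number from compound 2 to compound 3 (0.76 log units; beyond the scatter) when cyclopropyl replaces pentan-3-yl. No measured evidence is available to explain either step. The compounds shown leave open whether any group here gives a lower number than methyl, and whether a straight chain such as ethyl or a group carrying an amine fits between these values.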